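The source may hold more compounds than are shown below. What is called first, only, known or untested is meant among the compounds shown, and "the series" means these compounds.

Compounds measured so far:
- compound 1 `Cc1n[nH]c2c1C(c1ccc(N(C)C)cc1)C(C(N)=O)=C(N)N2` gives 5770 nM in a functional assay on HeLa cells (Homo sapiens) for cytotoxicity, read by MTT assay, with a stated time of 48 h; on this read-out higher numbers stand for weaker inhibition and lower numbers for stronger inhibition
- compound 2 `Cc1n[nH]c2c1C(c1ccc(N(C)C)cc1)C(C(=O)NNC(N)=S)=C(N)N2` gives 6260 nM in this assay

Compound 2 carries the highest number of the two in this assay, but its nearest neighbour, compound 1, sits within the scatter of it, so no order between them can be claimed. Going by the values given here, the one measured step, a 1.1-fold higher number from compound 1 to compound 2 (0.04 log units; within the scatter), replaced a hydrogen on the amide-type nitrogen with a group of four heavy atoms and left the read-out essentially unchanged.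

Compound 3 `Cc1n[nH]c2c1C(c1ccc(N(C)C)cc1)C(C(=O)O)=C(N)N2` is the next compound in this series. Relative to compound 2, it differs as follows: one oxygen atom in place of a group of 5 heavy atoms (1 carbon, 3 nitrogen, 1 sulfur; no ring), on a carbonyl carbon. Among the compounds with values here, the change sits on the same carbonyl-bearing arm that was altered between compound 1 and compound 2, where the only step at hand lay within the scatter. Within the data shown here, that single step is the only measured evidence bearing on compound 3, and it points to little effect from substitution at this arm. It does not, however, cover a change in which the whole group leaves and a hydroxy enters. On this basis the expected step is a 1.2-fold higher number from compound 2 to compound 3 (0.08 log units; within the scatter), within or close to the scatter. Compound 3 is therefore estimated at 7500 nM in this assay, with a range from 3000 nM to 25000 nM.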

Compound 3, half-maximal inhibitory concentration: 33600 nM
For compound 3 the middle estimate is 4.5-fold (0.65 log units) below the measured one, outside the stated range (above it).
By their numbers in this assay, from the lowest: compounds 1 and 2 (each within the scatter of the next); then compound 3.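

The arm on the carbonyl carbon turns out not to be indifferent to every change in this assay: hydroxy in place of amino gives a 5.8-fold higher number from compound 1 to compound 3 (0.77 log units; beyond the scatter), and one oxygen atom in place of the group of 5 heavy atoms gives a 5.4-fold higher number from compound 2 to compound 3 (0.73 log units; beyond the scatter). The earlier step, a 1.1-fold higher number from compound 1 to compound 2 (0.04 log units; within the scatter), had shown only that a large addition to the amide-type nitrogen leaves the read-out where it was, so compound 3 is the first sign in the series that this position can move the number at all, here towards weaker inhibition, though only modestly. Since compound 1 and compound 2 lie within the scatter of each other, the two new steps amount to one finding: both compounds with a nitrogen on the carbonyl carbon stand apart from the one with hydroxy there.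

Going by these compounds, what a methoxy group or a methylamino group on the same carbonyl carbon would give remains open, and with it whether the higher number belongs to hydroxy itself or to the loss of that nitrogen. On these data alone, it is also open whether the same step would appear with a chlorine in place of the dimethylamino group on the shared core. Nothing among the data offered explains the difference between compound 3 and the other two compounds.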